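This account rests on a few compounds, and the source may have more. Where it says the series, first, only, none or still open, it means among the compounds named here.

Measured compounds:
Compound 3, `C=C1CCC[C@H]2[C@](C)(CC[C@]3(C)CC[C@H]([C@@H](C)C(=O)O)OO3)[C@@H](C)CC[C@]12C`, gives 1890 nM in a functional assay on OVCAR-4 cells (Homo sapiens) for inhibition; on this read-out lower numbers stand for stronger inhibition of growth and higher numbers for weaker inhibition of growth.
Compound 1, `COC(=O)[C@H](C)[C@H]1CC[C@@](C)(CCC2=C(C)CCCC2(C)C)OO1`, reaches only a limit of this assay, > 25000 nM.
Compound 2, `C=C1CCCC(C)(C)C1(O)CC/C(C)=C/CC[C@]1(C)CC[C@@H]([C@@H](C)C(=O)OC)OO1`, likewise reaches only a limit of this assay, > 17500 nM.

Among the three values shown, compound 3 stands as the only one with a true number; the other two values are limits, as the lines the limit of > 17500 nM in this assay, at which 1 of the 3 values shown sits, and the limit of > 25000 nM in this assay, at which 1 of the 3 values shown sits, record. Within the data shown here, no step between measured compounds that differ in one place has been measured, so nothing in these data tells how a single change moves the read-out.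

Compound 4, `C=C1CCC[C@H]2[C@](C)(CC[C@]3(C)CC[C@@H]([C@@H](C)C(=O)O)OO3)[C@@H](C)CC[C@]12C`, is the next compound to be measured in this assay. Set against compound 3, the difference is the two compounds have the same atoms and bonds and differ only in configuration as drawn: 1 of 7 stereo elements differ; a stereocentre at a saturated ring carbon is drawn R in compound 3 and S in compound 4. Without any measured step to lean on, the expectation is a step from compound 3 to compound 4 of a 1.3-fold higher number from compound 3 to compound 4 (0.12 log units; within the scatter), small and most likely within the usual scatter, with a slight lean toward weaker inhibition. Compound 4 is therefore estimated at 2500 nM, with a range from 800 nM to 8000 nM.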

Compound 4, concentration for 50% growth inhibition: 950 nM
The estimate for compound 4 lay 2.6-fold (0.42 log units) above the measured number; the range from low to high includes it.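

In this assay, this pair supplies the first readable step among the compounds shown, a 2.0-fold lower number from compound 3 to compound 4 (0.30 log units; within the scatter), at a stereocentre at a saturated ring carbon that is drawn R in compound 3 and S in compound 4. The configuration at this carbon therefore does not separate the two compounds beyond the usual scatter, and both give a true number rather than a limit. The comparison rests on a single change: the fact that compounds 3 and 4 differ only in the configuration as drawn.

Among these compounds, compounds 1 and 2 differ from this pair in more than one place, so no step connects them to it. As far as these compounds go, it remains open how the other six stereo elements bear on the read-out, and how an amide or an amine in place of the carboxylic acid would read in this assay.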